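Antiproliferative series: aryl replaces phenylethenyl on saturated ring carbon

The source may hold more compounds than are shown below. What is called first, only, known or untested is meant among the compounds shown, and "the series" means these compounds.

Compound 1 `Cc1cc(O)c(C2=NN(c3ccc(S(N)(=O)=O)cc3)C(c3ccccc3O)C2)cc1Cl` — 2370 nM in a functional assay on HT-29 cells (Homo sapiens) for antiproliferative activity, with a stated time of 48 h; on this read-out higher numbers stand for weaker inhibition of growth and lower numbers for stronger inhibition of growth
Compound 2 `Cc1cc(O)c(C2=NN(c3ccc(S(N)(=O)=O)cc3)C(c3ccccc3Cl)C2)cc1Cl` — 1920 nM
Compound 3 `Cc1cc(O)c(C2=NN(c3ccc(S(N)(=O)=O)cc3)C(/C=C/c3ccccc3)C2)cc1Cl` — 3730 nM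

All three numbers sit within the usual scatter of one another: from compound 1 to compound 3 the step is a 1.6-fold higher number from compound 1 to compound 3 (0.20 log units; within the scatter), from compound 2 to compound 3 it is a 1.9-fold higher number from compound 2 to compound 3 (0.29 log units; within the scatter), and the aryl swap gives a 1.2-fold lower number from compound 1 to compound 2 (0.09 log units; within the scatter). Compound 4 `COc1ccc(C2CC(c3cc(Cl)c(C)cc3O)=NN2c2ccc(S(N)(=O)=O)cc2)cc1OC` differs from compound 3 by 3,4-dimethoxyphenyl in place of 2-phenylethenyl on a saturated ring carbon. The two steps that bear on it, both exchanges of an aryl for 2-phenylethenyl at this carbon, stayed within the scatter, so reversing that exchange with a different aryl is expected to move this assay little, if at all: the expected step is a 1.5-fold lower number from compound 3 to compound 4 (0.17 log units; within the scatter). Compound 4 is therefore estimated at 2500 nM, within 1000 nM to 6000 nM.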

Compound 4, concentration for 50% growth inhibition: 2240 nM
Compound 4: the middle estimate sits 1.1-fold (0.05 log units) above what was measured, and the stated range covers the measured number.
By their numbers in this assay, from the lowest: compounds 2, 4, 1 and 3 (each within the scatter of the next).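

The saturated ring carbon also accepts 3,4-dimethoxyphenyl without a step beyond the scatter in this assay: against 2-phenylethenyl the change gives a 1.7-fold lower number from compound 3 to compound 4 (0.22 log units; within the scatter), against 2-chlorophenyl a 1.2-fold higher number from compound 2 to compound 4 (0.07 log units; within the scatter), and against 2-hydroxyphenyl a 1.1-fold lower number from compound 1 to compound 4 (0.02 log units; within the scatter). All four groups at this carbon therefore lie within the scatter on every step printed, now including an aryl with two methoxy substituents. No supporting measurement is available to explain this flat response.

Still open, as far as these compounds go, is whether an aminomethyl or carboxylic acid group on this aryl would separate from these values. A saturated alkyl chain in place of the aryl at this carbon also remains untested in the compounds shown here.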